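The source may report more compounds than this note shows. Statements on the series, on what has been measured and on what is new or still open speak of the compounds shown alone.

The measured compounds and their values:

Compound 1, `COc1ccc(C(=O)/C=C\Nc2ccc(-c3nc4cc(OC)c(OC)c(OC)c4s3)cc2C)cc1O`: 11400 nM
Compound 2, `COc1ccc(C(=O)/C=C\Nc2ccc(-c3nc4cc(OC)c(OC)c(OC)c4s3)cc2)cc1O`: 14100 nM
Compound 3, `COc1cc(OC)c2sc(-c3ccc(N/C=C\C(=O)c4cc(OC)c(OC)c(OC)c4)c(C)c3)nc2c1`: 16400 nM

All three were tested in a functional assay on HeLa cells (Homo sapiens) for antiproliferative activity, read by sulforhodamine B assay, with a stated time of 48 h; on this read-out lower numbers stand for stronger inhibition and higher numbers for weaker inhibition. Compound 1 gives 11400 nM and compound 2 gives 14100 nM. The two differ in one place, (hydrogen in place of methyl on an aromatic carbon), and the step is a 1.2-fold higher number from compound 1 to compound 2 (0.09 log units; within the scatter), so the two values cannot be told apart. Compound 3 gives 16400 nM; its values and those of compound 1 and compound 2 all lie within the scatter of one another, so none of the three can be called stronger or weaker than another. Compound 3 carries a different core from compound 1; the difference between the two cores is not broken down here.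

The unmeasured compound 4, `COc1cc(OC)c2sc(-c3ccc(N/C=C\C(=O)c4cc(OC)c(OC)c(OC)c4)cc3)nc2c1`, is related to compound 3 by hydrogen in place of methyl on an aromatic carbon. This is the same change that links compound 1 to compound 2, made at a place described in the same words. Because the earlier step was a 1.2-fold higher number from compound 1 to compound 2 (0.09 log units; within the scatter), the step from compound 3 to compound 4 is expected to be small as well, estimated at a 1.2-fold higher number from compound 3 to compound 4 (0.06 log units; within the scatter). Compound 4 is therefore expected to give about 19000 nM in this assay, with a likely range from 9000 nM to 40000 nM.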

Compound 4, half-maximal inhibitory concentration: 17800 nM
Compound 4: middle estimate off by 1.1-fold (0.03 log units), on the high side, within the range that was stated.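

In this assay, hydrogen in place of methyl on an aromatic carbon of the core of compound 3 gives a 1.1-fold higher number from compound 3 to compound 4 (0.04 log units; within the scatter), and a step of that size cannot be told apart from the ordinary spread of repeated measurements. Set beside the earlier step, the change behaves alike on the two cores: the same change on two cores in this assay, a 1.2-fold higher number (0.09 log units; within the scatter) from compound 1 to compound 2 and a 1.1-fold higher number (0.04 log units; within the scatter) from compound 3 to compound 4, 1.1-fold (0.06 log units) apart, within the scatter of two such steps. So, for these two pairs, the methyl-to-hydrogen swap carries from one core to the other in the plain sense that neither core shows a step beyond the scatter, but this does not show that the swap would behave the same way on any further core, nor can steps this small reveal whether a slight real effect lies hidden in the scatter.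

The compounds shown carry only methyl or hydrogen at this place, so what an ethyl group, a chlorine atom, an amine or a carboxylic acid would do there stays open. As far as these compounds go, all four values also come from this assay alone, and all sit close together, so whether the swap would stay this small in other cells, or on a compound with a much lower number, is equally open.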